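Removing the carbamate chain from compound 1: a piperidine amide

The compounds below may be only part of what the source reports. "The series", "measured", "known", "first", "only" and "open" are said of these compounds alone.

Compound 1 `CC(C)(C)OC(=O)NCCCNC(=O)CN1CN(c2ccccc2)C2(CCN(C(=O)c3ccc(C4CCCCC4)cc3)CC2)C1=O` is measured in an assay on HEK293 cells for displacement of a labelled ligand from NPC1-like intracellular cholesterol transporter 1 (Homo sapiens) (on this read-out lower numbers stand for stronger inhibition and higher numbers for weaker inhibition), where compound 1 gives 6000 nM, the highest of the three numbers shown, though its gaps to the other two lie within the scatter. Compound 2 `CC(C)(C)OC(=O)NCCCNC(=O)CN1CN(c2ccccc2)C2(CCN(C(=O)c3ccc(C(C)(C)C)cc3)CC2)C1=O` gives 4500 nM, and the step of a 1.3-fold lower number from compound 1 to compound 2 (0.12 log units; within the scatter) is within the scatter. Compound 3 `CC(C)(C)OC(=O)NC1CCCN(C(=O)CN2CN(c3ccccc3)C3(CCN(C(=O)c4ccc(C(C)(C)C)cc4)CC3)C2=O)C1` gives 4200 nM; compound 2 and compound 3 differ only in the amide portion, and their two values also lie within the scatter of each other. Compound 4 `CC1CCCN(C(=O)CN2CN(c3ccccc3)C3(CCN(C(=O)c4ccc(C5CCCCC5)cc4)CC3)C2=O)C1` is not yet measured. It differs from compound 1 in one place: 3-methylpiperidin-1-yl in place of (3-((tert-butoxycarbonyl)amino)propyl)amino on a carbonyl carbon. Going by the values given here, no measured step covers the loss of the carbamate itself; the comparison of compound 2 with compound 3 only suggests that closing the amide nitrogen into a ring changes little. Compound 4 is therefore expected to stay near compound 1 in this assay, with a step of a 1.2-fold lower number from compound 1 to compound 4 (0.08 log units; within the scatter) that is not expected to exceed the scatter. The estimate for compound 4 is 5000 nM, in a range from 1200 nM to 20000 nM.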

Compound 4, half-maximal inhibitory concentration: 3600 nM
Compound 4: the middle estimate sits 1.4-fold (0.14 log units) above what was measured; the measured number falls inside the stated range.
By their numbers in this assay, from the lowest: compounds 4, 3, 2 and 1 (each within the scatter of the next).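

Exchanging (3-((tert-butoxycarbonyl)amino)propyl)amino on a carbonyl carbon for 3-methylpiperidin-1-yl gives a 1.7-fold lower number from compound 1 to compound 4 (0.22 log units; within the scatter) in this assay. Going by these compounds alone, compound 1, compound 2 and compound 3 all carry the tert-butoxycarbonyl carbamate, so compound 4 is the first to show that this position tolerates its complete removal, along with every hydrogen-bond donor and acceptor of the group, without a change beyond the scatter. Nothing available explains this result.

The compounds shown leave open whether a primary amine, a carboxylic acid or a longer alkyl chain on this carbonyl carbon would move the number beyond the scatter. They also leave open whether the methyl group on the piperidine matters, since plain piperidin-1-yl does not appear among them.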